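A few compounds are considered here, and "the series" means these few. Any claim that something is new, unique, unknown or untested is made for them only; others in the source may bear on it.

Compound 1 `O=C(CCCCCn1cc(Nc2ncc3ccn(Cc4ccccc4Cl)c3n2)cn1)NO`: 45 nM
Compound 2 `O=C(CCCCCCn1cc(Nc2ncc3ccn(Cc4ccccc4Cl)c3n2)cn1)NO`: 41.5 nM

In an assay on isolated protein for inhibition of protein deacetylase HDAC6 (Homo sapiens), with a stated time of 60 min (on this read-out higher numbers stand for weaker inhibition and lower numbers for stronger inhibition), compound 1 gives 45 nM and compound 2 gives 41.5 nM. The step of a 1.1-fold lower number from compound 1 to compound 2 (0.04 log units; within the scatter) lies within the scatter, so the two cannot be ordered; compound 1 simply holds the higher of the two numbers, with compound 2 as its nearest neighbour. Compound 3 `COc1cccc(Cn2ccc3cnc(Nc4cnn(CCCCCC(=O)NO)c4)nc32)c1` has not yet been measured. It differs from compound 1 by 3-methoxyphenyl in place of 2-chlorophenyl on a saturated chain carbon bound to an aromatic nitrogen. Within the data shown here, no measured step touches this change: the only step in hand, from compound 1 to compound 2, alters the chain that carries the hydroxycarbamoyl group and leaves the 2-chlorobenzyl group untouched, so it offers no guide to either direction or size. The step expected in this assay is therefore a 1.2-fold higher number from compound 1 to compound 3 (0.09 log units; within the scatter), held within the scatter and with wide uncertainty. Compound 3 is estimated at 55 nM, within a range from 15 nM to 220 nM.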

Compound 3, half-maximal inhibitory concentration: 37.6 nM
Beside the measured number, compound 3's estimate is 1.5-fold (0.17 log units) above it; the range from low to high includes it.
By their numbers in this assay, from the lowest: compounds 3, 2 and 1 (each within the scatter of the next).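

Among these compounds, the earlier compounds varied only the chain carrying the hydroxycarbamoyl group, whereas compound 3 is the first to show a change at the other end of the molecule. In this assay, going from 2-chlorobenzyl to 3-methoxybenzyl gives a 1.2-fold lower number from compound 1 to compound 3 (0.08 log units; within the scatter), so the two compounds cannot be ordered, and this place accepts the exchange of 2-chlorophenyl for 3-methoxyphenyl with no measurable difference. Nothing available explains this result.

Because the substituent and its place on the phenyl ring change together, the compounds shown cannot separate the two, and 3-chlorophenyl or 2-methoxyphenyl would be needed to do so. From the compounds shown here alone, it also remains open whether an amine or a carboxylic acid on that phenyl ring would move the number beyond the scatter.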